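Aryl thiosemicarbazones of a quinoline aldehyde: MCF7 cytotoxicity notes

The source may report more compounds than this note shows. Statements on the series, on what has been measured and on what is new or still open speak of the compounds shown alone.

Three compounds in this series share the same core and differ only in the aryl group on the thiourea nitrogen. Compound 1 `O=[N+]([O-])c1ccc(NC(=S)N/N=C\c2ccnc3ccccc23)cc1` gives 810 nM in a functional assay on MCF7 cells (Homo sapiens) for cytotoxicity, read by MTT assay, with a stated time of 48 h; on this read-out higher numbers stand for weaker inhibition and lower numbers for stronger inhibition. Compound 2 `S=C(N/N=C\c1ccnc2ccccc12)Nc1cccnc1` gives 970 nM in this assay, and compound 3 `S=C(N/N=C\c1ccnc2ccccc12)Nc1cccc2ccccc12` gives 880 nM. Compound 2 stands with the highest of the three numbers, but its gap to compound 3 and to compound 1 is within the scatter, so the three cannot be separated. Compound 4 `COc1ccc(NC(=S)N/N=C\c2ccnc3ccccc23)cc1` is not yet measured in this assay. The change from compound 2 is 4-methoxyphenyl in place of pyridin-3-yl on an amide-type nitrogen. The three measured values show that swapping one aryl group for another, whether a nitro-bearing phenyl, a pyridine or a naphthalene, leaves the number within the scatter, so for compound 4 no step beyond the scatter is expected in either direction. The step from compound 2 to compound 4 is therefore estimated at a 1.1-fold lower number from compound 2 to compound 4 (0.03 log units; within the scatter). Compound 4 is expected to give about 900 nM, with a range from 450 nM to 1800 nM, because compound 2 gives 970 nM and compound 3 gives 880 nM with a different aryl group.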

Compound 4, half-maximal inhibitory concentration: 990 nM
Compound 4: the middle estimate sits 1.1-fold (0.04 log units) below what was measured, within the range that was stated.
By their numbers in this assay, from the lowest: compounds 1, 3, 2 and 4 (each within the scatter of the next).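

In this assay, 4-methoxyphenyl in place of pyridin-3-yl on the amide-type nitrogen gives a 1.0-fold higher number from compound 2 to compound 4 (0.01 log units; within the scatter) and so adds a carbon-only ring carrying methoxy to the aryl groups that cannot be separated at this position. Methoxy in place of nitro on an aromatic carbon gives a 1.2-fold higher number from compound 1 to compound 4 (0.09 log units; within the scatter) and is the first step in the series that changes only a substituent on the phenyl ring, which also leaves the number within the scatter. No evidence at hand bears on this result.

Every group shown at this nitrogen is aromatic, so a saturated ring such as cyclohexyl or a short alkyl chain remains an open test. Also open, on these data alone, is whether a carboxylic acid or an aminomethyl group on the phenyl ring would produce a step beyond the scatter.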